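Methyl to chloro against an assay limit

This account rests on a few compounds, and the source may have more. Where it says the series, first, only, none or still open, it means among the compounds named here.

Measured so far in a functional assay on HCT-116 cells (Homo sapiens) for inhibition, read by MTT assay, with a stated time of 2 days; on this read-out lower numbers stand for higher toxicity in this test and higher numbers for lower toxicity in this test:
- Compound 1 `Nc1ccccc1NC(=O)c1ccc(NCC(=O)Nc2ccc([N+](=O)[O-])cc2)cc1`: > 100000 nM, a limit
- Compound 2 `Cc1ccc(NC(=O)CNc2ccc(C(=O)Nc3ccccc3N)cc2)cc1`: > 100000 nM, a limit

Compound 2 stands at > 100000 nM, which is a limit of the assay and not a number. It therefore offers no exact starting point for the next comparison.

Compound 3 `Nc1ccccc1NC(=O)c1ccc(NCC(=O)Nc2ccc(Cl)cc2)cc1` differs from compound 2 in a single substituent (chloro in place of methyl on an aromatic carbon). Its chloro group sits para to a large group, where compound 2 carries methyl.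

Going by the values given here, the one measured step bearing on this change is a step that the two limits leave unreadable from compound 1 to compound 2, where methyl takes the place of nitro on an aromatic carbon. That step gives no size to carry over. Among the compounds with values here, the only further evidence is the limit of > 100000 nM in this assay, at which 2 of the 2 values shown sit.

With compound 2 at > 100000 nM, a limit, no step beyond the scatter is expected in this assay. The estimated step is a number no higher from compound 2 to compound 3 (the limit leaves the size open), and a report of only a limit is the likeliest outcome. For compound 3 the expected value is 100000 nM, with an estimated range from 40000 nM to 250000 nM.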

Compound 3, concentration lethal to 50% of the cells: > 100000 nM
Compound 3 gave a limit, no number; the forecaster's own chance of this, stated with the estimate: 70%; the middle value sits exactly at the limit.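

Going by these compounds alone, compound 1, compound 2 and compound 3 each give only a limit in this assay, not a number, so no step among them can be read: the limit of > 100000 nM in this assay, at which 3 of the 3 values shown sit.

The compounds shown leave open whether nitro, methyl and chloro on this aromatic carbon differ at all in this assay, and by how much.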